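The compounds below may be only part of what the source reports. "The series", "measured", "known", "first", "only" and "open" are said of these compounds alone.

Compound 1 `C=C1CN(C)/C(=N/c2ccccc2)S1`: > 100000 nM (a limit)
Compound 2 `COc1ccc(/C=C2\S/C(=N\c3ccc(C)c(Cl)c3)N(C)C2=O)cc1`: 14100 nM
Compound 3 `COc1ccc(/C=C2\S/C(=N\c3ccc(C(C)(C)C)cc3)N(C)C2=O)cc1`: > 100000 nM (a limit)

These three compounds were tested in a functional assay on HCT-116 cells (Homo sapiens) for antiproliferative activity, read by MTT assay, with a stated time of 72 h; a higher number here means a weaker inhibitor, a lower number a stronger inhibitor. For the measured compounds named here, compound 2 is the only one that gives a number, 14100 nM. Compound 1 reads > 100000 nM, which is a limit of the assay and not a number. Compound 3 reads > 100000 nM, which is also a limit. The evidence so far is therefore thin, with the limit of > 100000 nM in this assay, at which 2 of the 3 values shown sit.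

Compound 4 `COc1ccc(/C=C2\S/C(=N\c3c(C)cccc3C)N(C)C2=O)cc1` has not yet been measured. It carries 2,6-dimethylphenyl in place of the 3-chloro-4-methylphenyl of compound 2 on a double-bonded nitrogen: 2,6-dimethylphenyl in place of 3-chloro-4-methylphenyl on a double-bonded nitrogen. Going by the values given here, no measured pair isolates this change, so its size can only be judged loosely. A moderate step towards higher numbers is expected in this assay, and the reading may reach the limit. This expectation leans on compound 3, whose reading of > 100000 nM is a limit. The expected step is a 2.8-fold higher number from compound 2 to compound 4 (0.45 log units; beyond the scatter). Compound 4 is estimated at 40000 nM, with an expected range from 12000 nM to 100000 nM.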

Compound 4, half-maximal inhibitory concentration: > 100000 nM
Compound 4: a limit, no number; the forecaster's own chance of this, stated with the estimate: 40%; middle value at least 2.5-fold (0.39 log units) away from the limit.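

In this assay, for the compounds shown here, the change to 2,6-dimethylphenyl in place of 3-chloro-4-methylphenyl on a double-bonded nitrogen gives the first step that can be read at this position: an at least 7.0-fold higher number from compound 2 to compound 4 (0.85 log units; beyond the scatter). Both groups count 8 heavy atoms and one six-membered aromatic ring of carbon only, so this position separates two aryl groups of equal heavy-atom count, and the step gives only a minimum size, as the reading of compound 4 is a limit of the assay and not a number. Compound 2 remains the only compound with a number: the limit of > 100000 nM in this assay, at which 3 of the 4 values shown sit.

The compounds shown leave open whether the loss follows the chlorine that leaves or the arrangement of the methyl groups, as the two change together. They also leave open whether a phenyl group carrying an amine or a carboxylic acid on this nitrogen would give a lower number than compound 2.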